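A few compounds are considered here, and "the series" means these few. Any claim that something is new, unique, unknown or untested is made for them only; others in the source may bear on it.

Measured so far:
- compound 1, `Nc1ccccc1NC(=O)/C=C/c1ccc(Cn2cnc3c(NC4CCCCC4)nc(Cl)nc32)cc1`: 8.09%
- compound 2, `CC(C)n1cnc2c(Nc3ccccc3)nc(NCOCc3ccc(C(=O)Nc4ccccc4N)cc3)nc21`: 15%

In a functional assay on NCI-H460 cells (Homo sapiens) for antiproliferative activity, read by CCK-8 assay, with a stated time of 72 h, tested at 2 uM (on this read-out lower numbers stand for a weaker effect and higher numbers for a stronger effect at the one concentration tested), compound 1 gives 8.09%. Compound 2 gives 15% in this assay. Compound 1 stands at one end of the two numbers, with compound 2 close by; the gap between them lies within the scatter, so the two are not distinguished, and both sit at a low level of inhibition at the single concentration tested.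

Compound 3, `Nc1ccccc1NC(=O)/C=C/c1ccc(Cn2cnc3c(Nc4cccc(OC(F)(F)F)c4)nc(Cl)nc32)cc1`, is still to be measured. It differs from compound 1 in one place: 3-(trifluoromethoxy)phenyl in place of cyclohexyl on a nitrogen on an aromatic ring. Among the measured compounds shown here, no pair of measured compounds shows the effect of such an exchange, so nothing in the two numbers points to a direction. The expected step from compound 1 to compound 3 is a number 6.9 percentage points higher from compound 1 to compound 3 (within the scatter), not clearly beyond the scatter. For compound 3 the estimated value in this assay is 15%, in a range from 0% to 40%.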

Compound 3, a percentage reported as inhibition, at one concentration (the size of the read-out at that concentration, not a potency): 2.1%
Compound 3: middle estimate off by 12.9 percentage points, on the high side; the measured number falls inside the stated range.
By their numbers in this assay, from the lowest: compounds 3, 1 and 2 (each within the scatter of the next, the first and the last beyond it).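

In this assay, among the compounds shown here, 3-(trifluoromethoxy)phenyl in place of cyclohexyl on a nitrogen on an aromatic ring gives a number 6 percentage points lower from compound 1 to compound 3 (within the scatter), the first direct reading of a change at this position. An aromatic ring with 11 heavy atoms in the entering group, against 6 in the leaving one, therefore produces no shift that stands clear of the scatter, and inhibition stays low at the single concentration tested. No available data bear on why these two groups are not distinguished.

The compounds shown leave open whether an unsubstituted phenyl, a short alkyl chain such as ethyl, or a ring carrying a carboxylic acid on this nitrogen would read differently. Also open, from the compounds shown here alone, is whether compound 1 and compound 3 would separate at a higher concentration in this assay.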